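Cytotoxicity screen of a shared amide series: compound 4 outlook

The source may hold more compounds than are shown below. What is called first, only, known or untested is meant among the compounds shown, and "the series" means these compounds.

Measured compounds:
compound 1 `O=C(Nc1ccc(Cl)cn1)C1CCCN(C(=O)c2cc(C(F)(F)F)cc(C(F)(F)F)c2)C1`, 0%
compound 2 `O=C(Nc1cccc(Oc2ccccn2)c1)C1CCCN(C(=O)c2cc(C(F)(F)F)cc(C(F)(F)F)c2)C1`, 0%
compound 3 `Cc1cccc(C(=O)N2CCCC(C(=O)Nc3ccc(Cl)cc3)C2)c1`, 0%

In an ADME assay on PC-3 cells (Homo sapiens) for cytotoxicity, read by WST assay, tested at 100 uM (on this read-out lower numbers stand for less inhibition and higher numbers for more inhibition at the one concentration tested (going by the name of the read-out)), compound 1 gives 0%. Compound 2, which carries a different aromatic group on the amide nitrogen, gives 0% in this assay. Compound 3, with a methyl-bearing benzoyl group and a chlorophenyl amide, gives 0%. Compound 3 thus stands level with compounds 1 and 2 at the digits shown; its nearest neighbour on the read-out is compound 1 and its furthest compound 2, and both gaps lie within the scatter, so no order among the three can be stated. Across the set, changes at both amide ends leave the read-out at the same figure.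

Compound 4 `O=C(Nc1ccc(Cl)cc1)C1CCCN(C(=O)c2cccc(-c3cccs3)c2)C1` is not yet measured. It differs from compound 3 as follows: thiophen-2-yl in place of methyl on an aromatic carbon

Among the measured compounds shown here, no single-point step between measured compounds is available for this kind of change. Given that every measured analogue sits at the floor of the read-out, the step from compound 3 to compound 4 is expected to stay within the scatter, with no direction: no change at the digits printed from compound 3 to compound 4 (within the scatter). For compound 4 the estimated read-out in this assay is 0%, expected to fall between -5% and 15%.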

Compound 4, a percentage reported as inhibition, at one concentration (the size of the read-out at that concentration, not a potency): 4%
Compound 4: middle estimate off by 4 percentage points, on the low side, and the stated range covers the measured number.
By their numbers in this assay, from the lowest: compounds 1, 2, 3 and 4 (each within the scatter of the next).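

Putting thiophen-2-yl in place of methyl on an aromatic carbon, meta to a large group, gives a number 4 percentage points higher from compound 3 to compound 4 (within the scatter) in this assay. Among the compounds shown here, this is the first comparison that isolates one place, and it shows that this position can carry a five-membered aromatic ring containing sulfur instead of a single methyl carbon without separating the two compounds on this read-out. Nothing on hand explains the outcome at this position.

The compounds shown leave open whether a charged or strongly hydrogen-bonding substituent at this position, such as an aminomethyl group or a carboxylic acid, would also stay level with compound 3 in this assay, since the only groups seen here are methyl and thiophen-2-yl. They also leave open whether a longer chain, such as an n-butyl group, or a second ring joined through an ether oxygen would move the read-out clear of the scatter at this same position.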